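The compounds below may be only part of what the source reports. "The series", "measured", "known", "first", "only" and "open" are said of these compounds alone.

Working notes on the series. The shared core carries an aryloxyacetamide side chain; three analogues have been measured in a toxicity assay on HepG2 cells (Homo sapiens) for inhibition, read by CellTiter-Glo, with a stated time of 48 h; on this read-out lower numbers stand for stronger inhibition and higher numbers for weaker inhibition. Compound 1 `CCCc1cc(OCC(=O)Nc2cc(C)cc(C)c2)c2cc(OC)ccc2n1` gives 12600 nM in this assay. Within the data shown here, compound 2 `COc1ccc2nc(C)cc(OCC(=O)Nc3cc(C)ccc3C)c2c1` differs from compound 1 in two places, so no single step connects them. In this assay compound 2 reaches only the limit of the assay, > 100000 nM. Compound 3 `COc1cccc(NC(=O)COc2cc(C)nc3ccc(OC)cc23)c1` likewise reaches only the limit in this assay, > 100000 nM. Among the measured compounds shown here, the one single-point step measured so far, a step that the two limits leave unreadable from compound 2 to compound 3, is unreadable, as the limit of > 100000 nM in this assay, at which 2 of the 3 values shown sit, covers both ends of it. Compound 3 therefore stands at the limit, with no numbered value to anchor it.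

Compound 4 `COc1ccc2nc(C)cc(OCC(=O)Nc3ccc(Cl)cc3Cl)c2c1` is reached from compound 3 by the change (2,4-dichlorophenyl in place of 3-methoxyphenyl on an amide-type nitrogen). For the measured compounds named here, no measured step bears directly on an exchange of the group on the amide-type nitrogen against a 2,4-dichlorophenyl, and the only measured exchange on that nitrogen gave no readable size. The expectation for compound 4 rests on the weak values at this position and is worded with caution. For compound 4 in this assay the estimate is 70000 nM, with a range from 15000 nM to 150000 nM. The step this estimate implies from compound 3 to compound 4 is an at least 1.4-fold lower number from compound 3 to compound 4 (0.15 log units; that floor lies within the scatter), and it is expected to remain within the limit region where compound 3 sits.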

Compound 4, half-maximal inhibitory concentration: > 100000 nM
Compound 4 gave a limit, no number (the forecaster's own chance of this, stated with the estimate: 55%); middle value at least 1.4-fold (0.15 log units) from the limit.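

In this assay compound 4 gives > 100000 nM as a limit, not a number. No new step can be read, as the steps from compound 2 and from compound 3 to compound 4 are both closed by it: the limit of > 100000 nM in this assay, at which 3 of the 4 values shown sit. Left open is whether any exchange on the amide-type nitrogen gives a readable step in this assay at all.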